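Acetamide series: chloro to iodo at compound 4

A few compounds are considered here, and "the series" means these few. Any claim that something is new, unique, unknown or untested is made for them only; others in the source may bear on it.

Measured in a functional assay on MCF7 cells (Homo sapiens) for antiproliferative activity; on this read-out higher numbers stand for weaker inhibition and lower numbers for stronger inhibition:
compound 1 `Nc1ccc(-c2nc3ccccc3s2)cc1Cl` gives < 1 nM (a limit)
compound 2 `Nc1ccc(-c2nc3ccccc3s2)cc1Br` gives < 1 nM (a limit)
compound 3 `CC(=O)Nc1ccc(-c2nc3ccccc3s2)cc1Cl` gives > 10 nM (a limit)

Compound 3 holds only the limit > 10 nM in this assay and no number. Compounds 1 and 2 sit at the other end (the limit of < 1 nM in this assay, at which 2 of the 3 values shown sit). Compound 4 `CC(=O)Nc1ccc(-c2nc3ccccc3s2)cc1I` carries iodo in place of chloro on an aromatic carbon, ortho to an acetamido group (iodo in place of chloro on an aromatic carbon). The acetyl step (an at least 10-fold higher number from compound 1 to compound 3 (1.00 log units; beyond the scatter)) lies beyond the scatter and places the acetamide on the higher side. Among the measured compounds shown here, the only halogen step (a step that the two limits leave unreadable from compound 1 to compound 2) gives no size, and iodo has no measured precedent here. The step expected for this swap is none beyond the scatter (a step that the limit leaves unreadable from compound 3 to compound 4). For compound 4 the estimated value in this assay is 20 nM (expected range 2 nM to 200 nM).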

Compound 4, half-maximal inhibitory concentration: > 100 nM
Compound 4: a limit, no number; the forecaster's own chance of this, stated with the estimate: 60%; at least 5.0-fold (0.69 log units) between middle value and limit.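

The step from compound 3 to compound 4, iodo in place of chloro, cannot be read: both values are limits, not numbers. As far as these compounds go, whether this swap shifts the value at all in this assay, and by how much, stays open.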